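A few compounds are considered here, and "the series" means these few. Any claim that something is new, unique, unknown or untested is made for them only; others in the source may bear on it.

Values in an ADME assay on S9 fraction from liver (Homo sapiens) for metabolic stability, read by LC-MS, using NADPH, with stated times of 5 min and 60 min, tested at 5 uM (on this read-out lower numbers stand for a less stable compound and higher numbers for a more stable compound), so far:
compound 1 `COc1ccc(COc2ccc(C3CN(C(=O)c4cc(OCCO)ccn4)C3)cc2OC)cc1` gives 38%
compound 2 `COc1cc(C2CN(C(=O)c3cc(OC[C@@H](O)CO)ccn3)C2)ccc1OCc1ccc(C2CC2)cc1` gives 63%

Compound 2 holds the higher of the two numbers, and its gap to compound 1 lies beyond the scatter of repeated measurements. The two compounds differ in more than one place, so this gap cannot be assigned to any single structural change.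

The next compound is compound 3 `COc1cc(C2CN(C(=O)c3cc(COCC(CO)(CO)CO)ccn3)C2)ccc1OCc1ccc(C2CC2)cc1`, which differs from compound 2 in one place: (3-hydroxy-2,2-bis(hydroxymethyl)propoxy)methyl in place of 2,3-dihydroxypropoxy on an aromatic carbon. Here (3-hydroxy-2,2-bis(hydroxymethyl)propoxy)methyl stands in place of 2,3-dihydroxypropoxy on an aromatic carbon, opposite the ring nitrogen.

Among the measured compounds shown here, no measured pair shows a single-place change, so the data give no direct guide to this exchange. The starting point is therefore compound 2 at 63% in this assay, and no change beyond the scatter is expected. The expected move, a number 5 percentage points lower from compound 2 to compound 3 (within the scatter), is small and leans slightly downward. Compound 3 is estimated at 58% with an expected range from 38% to 78% in this measurement.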

Compound 3, percent of the compound remaining: 85%
For compound 3 the middle estimate is 27 percentage points below the measured one; measured number above the stated range.
By their numbers in this assay, from the lowest: compound 1; then compound 2; then compound 3.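

In this assay, among the compounds shown here, (3-hydroxy-2,2-bis(hydroxymethyl)propoxy)methyl in place of 2,3-dihydroxypropoxy gives the first single-place reading, with a number 22 percentage points higher from compound 2 to compound 3 (beyond the scatter) at the aromatic carbon opposite the ring nitrogen. This position is therefore not silent in this read-out, and the side chain there can grow from 6 to 10 heavy atoms, with the one defined stereocentre gone, while the number rises rather than falls. Nothing on hand bears on the reason for this step.

The two side chains differ in size, in their counts of hydrogen-bond donors and acceptors, and in the presence of a stereocentre, and this single pair cannot separate these differences. Also open, on these data alone, is how this position responds to a side chain of another kind, such as one ending in an amine or a carboxylic acid, or a longer chain, and whether the step seen here carries over to other substituents elsewhere on the shared core.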